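The compounds below may be only part of what the source reports. "The series", "measured", "known", "first", "only" and "open" are said of these compounds alone.

Compound 1 `COc1ccc(CO/N=C/c2c(-c3ccc4ccccc4c3)nc3occn23)cc1` has the higher of the two numbers recorded in an assay on HepG2 cells for agonist activity at nuclear receptor subfamily 1 group I member 3 (Homo sapiens), read by a luciferase reporter, with a stated time of 23 h; a lower number here means that less compound is needed, a higher number that more compound is needed for the effect: compound 1 gives 4400 nM. Among the compounds with values here, its only measured partner is compound 2 `Fc1c(F)c(F)c(CO/N=C/c2c(-c3ccc4ccccc4c3)nc3occn23)c(F)c1F`, which in this assay gives 1700 nM; the step of a 2.6-fold lower number from compound 1 to compound 2 (0.41 log units; beyond the scatter) is the single comparison available.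

Compound 3 `C(=N/OC1Cc2ccccc2C1)\c1c(-c2ccc3ccccc3c2)nc2occn12` is not yet measured. It differs from compound 1 in one place: 2,3-dihydro-1H-inden-2-yl in place of 4-methoxybenzyl on an oxygen. This exchange removes the whole 4-methoxybenzyl group and puts a 2,3-dihydro-1H-inden-2-yl in its place on the oxygen, whereas the measured step only swapped the ring at the far end of that benzyl group. Within the data shown here, the one step that bears on it, a 2.6-fold lower number from compound 1 to compound 2 (0.41 log units; beyond the scatter), showed that a change to the group on that oxygen can move this assay by a modest amount, and it moved towards a lower number. Among the measured compounds shown here, with only that step to go on, a change of similar or smaller size is expected for compound 3, with wide uncertainty.

The estimate for compound 3 in this assay is 2500 nM, within 700 nM to 9000 nM, corresponding to an expected step of a 1.8-fold lower number from compound 1 to compound 3 (0.25 log units; within the scatter).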

Compound 3, half-maximal effective concentration: 980 nM
For compound 3 the middle estimate is 2.6-fold (0.41 log units) above the measured one, within the range that was stated.
By their numbers in this assay, from the lowest: compounds 3 and 2 (each within the scatter of the next); then compound 1.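

The exchange gives a 4.5-fold lower number from compound 1 to compound 3 (0.65 log units; beyond the scatter) in this assay and so shows that the number can fall when the whole group on this oxygen is replaced, not only when the ring at its far end is changed. The entering 2,3-dihydro-1H-inden-2-yl has the same count of heavy atoms as the leaving 4-methoxybenzyl, but it adds a five-membered non-aromatic ring and carries no hydrogen-bond acceptor, and compound 3 at 980 nM stands within the scatter of compound 2 at 1700 nM even though the two carry quite different groups here. Nothing given here explains why either exchange lowers the number.

On these data alone, it remains open whether a plain benzyl or a simple chain such as n-butyl on this oxygen would give a similar number, which would help separate the effect of the ring from that of the group's size. As far as these compounds go, it is also open how this assay would respond to a group bearing an amine or a carboxylic acid at the same place.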